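This account rests on a few compounds, and the source may have more. Where it says the series, first, only, none or still open, it means among the compounds named here.

Compound 1 `Cc1ccc(SCc2ccc(/C=C/C(=O)Nc3ccccc3N)cc2)cc1` was run in a functional assay on SMMC-7721 cells (Homo sapiens) for inhibition, read by CCK-8 assay, with a stated time of 72 h, tested at 2 uM (a higher number here means more inhibition of growth at the concentration tested, a lower number less inhibition of growth), where compound 1 gives 22%. A second compound, compound 2 `Nc1ccccc1NC(=O)c1ccc(CSc2nccc(C(F)(F)F)n2)cc1`, is built differently in several places; in this assay compound 2 gives 66.1%, so compound 1 holds the lower of the two numbers, and the gap between them lies beyond the usual scatter. Compound 3 `Nc1ccccc1NC(=O)/C=C/c1ccc(CSc2cccc(F)c2)cc1` differs from compound 1 in one place: 3-fluorophenyl in place of 4-methylphenyl on a sulfur. Among the measured compounds shown here, no measured pair shows what such an exchange does here, so only a small step is expected, a number 6 percentage points higher from compound 1 to compound 3 (within the scatter), with no direction that can be relied on. Compound 3 is therefore estimated to give 28%, within 12% to 48%.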

Compound 3, percent growth inhibition at one concentration: 8.56%
Estimate against measurement, compound 3: 19.4 percentage points above; measured number outside the range, below it.
By their numbers in this assay, from the lowest: compound 3; then compound 1; then compound 2.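

On the sulfur of the shared core, the choice of aryl group matters: in this assay the exchange of 4-methylphenyl for 3-fluorophenyl brings a number 13.4 percentage points lower from compound 1 to compound 3 (beyond the scatter) even though both groups have the same count of heavy atoms. Nothing measured here gives a reason for this drop. The exchange alters both the substituent and where it sits on the ring, and these two changes cannot be told apart from these compounds. Also open, on these data alone, is how 4-fluorophenyl, 3-methylphenyl or a ring carrying a carboxylic acid would behave on the same sulfur.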